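This account rests on a few compounds, and the source may have more. Where it says the series, first, only, none or still open, it means among the compounds named here.

Within the data shown here, compound 1 `Cn1sc2cc(OCc3cccc(-c4ccc(Cl)c(C(=O)O)c4)c3)ccc2c1=O` is the more stable of the two compounds measured so far. In an ADME assay on microsomes from liver (Rattus norvegicus) for metabolic stability, read by LC-MS, with a stated time of 1 h, at 37 degrees C, tested at 4 uM (a higher number here means that more of the compound is left, a lower number that less of the compound is left), compound 1 gives 84%, the higher of the two numbers. The second compound, compound 2 `O=C(O)c1ccc(Cl)c(-c2cccc(COc3ccc4c(c3)CN(C3CCCC3)C4=O)c2)c1`, gives in this assay a value of 15%, which lies far below compound 1 and well beyond the usual scatter of this kind of measurement. Compound 2 shares the acid-bearing part of compound 1 but carries a different core, so its gap to compound 1 cannot be traced to any single change.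

The next compound, compound 3 `CC(C)Cn1sc2cc(OCc3cccc(-c4ccc(Cl)c(C(=O)O)c4)c3)ccc2c1=O`, differs from compound 1 in one place: isopropyl in place of hydrogen on a saturated chain carbon bound to an aromatic nitrogen. Among the measured compounds shown here, no measured pair in this set shows what such a change does here. A moderate drop is expected, with the step from compound 1 to compound 3 estimated at a number 29 percentage points lower from compound 1 to compound 3 (beyond the scatter). Compound 3 is therefore expected to give 55% in this assay, within a range of 25% to 85%.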

Compound 3, percent of the compound remaining: 86%
Compound 3: middle estimate off by 31 percentage points, on the low side, and the stated range ends below it.
By their numbers in this assay, from the lowest: compound 2; then compounds 1 and 3 (each within the scatter of the next).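

In this assay, isopropyl in place of hydrogen on a saturated chain carbon bound to an aromatic nitrogen gives a number 2 percentage points higher from compound 1 to compound 3 (within the scatter). Among these compounds, this is the first direct reading at this position: on the core of compound 1, the change from methyl to isobutyl leaves the percent of compound remaining indistinguishable from that of the parent. No measurement shown here explains why the two compounds match.

The compounds shown leave open whether a longer chain, a phenyl ring or an amine at the end of the chain would also keep the percent remaining in this range. A single step also cannot tell whether the same change would behave alike on a different core.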